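The source may report more compounds than this note shows. Statements on the series, on what has been measured and on what is new or still open speak of the compounds shown alone.

Measured so far in an ADME assay on L6 cells (Rattus norvegicus) for cytotoxicity, read by resazurin assay, with a stated time of 72 h; a lower number here means a stronger inhibitor, a higher number a weaker inhibitor:
- compound 1 `Cc1ccc(C(=O)NC(=O)c2ccccc2O)cc1`: 46 ug/mL
- compound 2 `O=C(NC(=O)c1ccccc1O)c1ccc(-c2ccccc2)cc1`: > 100 ug/mL (a limit of the assay, not a number)
- compound 3 `COc1ccc(C(=O)NC(=O)c2ccccc2O)cc1`: 39 ug/mL

Compound 3 stands level with compound 1, as a 1.2-fold lower number from compound 1 to compound 3 (0.07 log units; within the scatter) shows. Compound 2 carries the only limit in the set, as the limit of > 100 ug/mL in this assay, at which 1 of the 3 values shown sits, records. Against that limit, the reading is an at least 2.5-fold lower number from compound 2 to compound 3 (0.40 log units; beyond the scatter).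

Next is compound 4 `CN(C)c1ccc(C(=O)NC(=O)c2ccccc2O)cc1`, with dimethylamino in place of methoxy on an aromatic carbon, para to a large group (dimethylamino in place of methoxy on an aromatic carbon).

Two kinds of measured step bear on this change at the same place on the shared core. Exchanging one ringless group for another made no difference beyond the scatter, as seen for compound 3 in a 1.2-fold lower number from compound 1 to compound 3 (0.07 log units; within the scatter). The phenyl group did move the number in this assay, in an at least 2.1-fold higher number from compound 1 to compound 2 (0.33 log units; beyond the scatter). Dimethylamino brings no ring, so compound 4 is expected to follow the first kind of step rather than the second. The expected change is a 1.1-fold lower number from compound 3 to compound 4 (0.03 log units; within the scatter), which means no step beyond the scatter in either direction. For compound 4 the estimated value is 36 ug/mL, with an expected range of 16 ug/mL to 80 ug/mL.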

Compound 4, half-maximal inhibitory concentration: 54 ug/mL
Compound 4: the middle estimate sits 1.5-fold (0.18 log units) below what was measured, within the range that was stated.
By their numbers in this assay, from the lowest: compounds 3, 1 and 4 (each within the scatter of the next). At a limit, above all of these: compound 2.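

In this assay dimethylamino, on an aromatic carbon para to a large group, joins methyl and methoxy as a third ringless group that gives no step beyond the scatter (a 1.4-fold higher number from compound 3 to compound 4 (0.14 log units; within the scatter); a 1.2-fold higher number from compound 1 to compound 4 (0.07 log units; within the scatter)). Replacing methoxy with dimethylamino exchanges oxygen for nitrogen and adds a carbon, with the same counts of hydrogen-bond donors and acceptors, and the reading still does not separate from those of compounds 1 and 3, so among the ringless groups shown the position tolerates this change in this assay. Compound 4 is not clearly separated from compound 2, whose reading is a limit and not a number, unlike compound 3, since the step (an at least 1.8-fold lower number from compound 2 to compound 4 (0.26 log units; that floor lies within the scatter)) is only a floor: the limit of > 100 ug/mL in this assay, at which 1 of the 4 values shown sits.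

Still open, on these data alone, is whether any ringless group moves the number at this position, as a primary amine, a carboxylic acid or a longer chain such as butoxy would show. Also open, as far as these compounds go, is whether the reading of compound 2 belongs to an added ring as such, which a cyclohexyl or pyridyl group at the same place would help to settle.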